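Hemolysis screen of a thiosemicarbazone series: three limits

The source may hold more compounds than are shown below. What is called first, only, known or untested is meant among the compounds shown, and "the series" means these compounds.

Measured so far:
compound 1 `CC(=NNC(=S)Nc1cccc([N+](=O)[O-])c1)c1ccccn1` in an ADME assay on cells (Erythrocyte, Homo sapiens), read by hemolysis, with a stated time of 1 h (a higher number here means a weaker inhibitor, a lower number a stronger inhibitor), gives > 10000 nM, a limit of the assay.
compound 2 `CC(=NNC(=S)Nc1cccc(F)c1)c1ccccn1` in this assay gives > 10000 nM, a limit of the assay.
compound 3 `CC(=NNC(=S)Nc1ccc(F)cc1)c1ccccn1` in this assay gives > 10000 nM, a limit of the assay.

None of the three compounds has a number in this assay; each value is only a limit, and (the limit of > 10000 nM in this assay, at which 3 of the 3 values shown sit). From compound 2 to compound 1 the change is nitro in place of fluoro on an aromatic carbon, and the step that the two limits leave unreadable from compound 2 to compound 1 cannot be read, since both ends sit at the limit. Compound 2 and compound 3 carry the same atoms joined differently; the difference between the two cores is not broken down here.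

Compound 4 `CC(=NNC(=S)Nc1ccc([N+](=O)[O-])cc1)c1ccccn1` remains to be measured. It differs from compound 3 by nitro in place of fluoro on an aromatic carbon, the same kind of change as that from compound 2 to compound 1, but the place is not the same: in the earlier pair the group is meta to a large group, here it is para to a large group.

Expectation for compound 4 in this assay: the step that the limit leaves unreadable from compound 3 to compound 4 is estimated to be small or unreadable, resting on compound 3 sitting at the limit > 10000 nM and on (the limit of > 10000 nM in this assay, at which 3 of the 3 values shown sit), with the earlier step that the two limits leave unreadable from compound 2 to compound 1 giving no readable size. Compound 4 is therefore expected to give about 20000 nM, with a range from 10000 nM to 60000 nM, most likely reported as a limit again.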

Compound 4, half-maximal inhibitory concentration: > 10000 nM
Compound 4 gave a limit, no number; the forecaster's own chance of this, stated with the estimate: 90%; the middle value is on the limit's open side.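

In this assay compound 4 gives > 10000 nM, a limit of the assay and not a number. No new step can be read between compound 3 and compound 4, since both ends sit at the same limit: the limit of > 10000 nM in this assay, at which 4 of the 4 values shown sit. The compounds shown leave open whether nitro in place of fluoro changes the read-out at all, and whether any of the four compounds differ from one another in this assay.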